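The compounds below may be only part of what the source reports. "The series", "measured", "known", "first", "only" and "open" are said of these compounds alone.

Among the measured compounds shown here, in a functional assay on HepG2 cells (Homo sapiens) for inhibition, read by scintillation counting, with a stated time of 2 h (a lower number here means a stronger inhibitor, a higher number a weaker inhibitor), compound 1 (`CCNC(=O)Nc1sc2ccccc2c1C(=O)N1CCN(C2CCN(C(=O)C3CCN(C(C)=O)CC3)CC2)CC1`) has the entry "not determined" (no result reported), so compound 2 (`CCNC(=O)Nc1sc2ccccc2c1C(=O)N1CCN(C2CCN(C(=O)OC(C)(C)C)CC2)CC1`), at 79 nM, holds the only number available and cannot yet be ranked against anything. Compound 3 (`CCNC(=O)Nc1sc2ccccc2c1C(=O)N1CCN(C2CCN(C(=O)OC(C)(C)CF)CC2)CC1`) alters compound 2 in one place: fluoro in place of hydrogen on a saturated chain carbon, two bonds along the chain from an oxygen next to a carbonyl group, with fluoro in place of hydrogen on a saturated chain carbon, two bonds along the chain from an oxygen next to a carbonyl group. For the measured compounds named here, no measured pair shows this change, so no shift beyond the scatter is expected in this assay. The estimated change is a 1.0-fold higher number from compound 2 to compound 3 (0.01 log units; within the scatter). For compound 3, the expected value is 80 nM, within an estimated range of 30 nM to 220 nM.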

Compound 3, half-maximal inhibitory concentration in the HepG2 assay: 61 nM
Compound 3: the middle estimate sits 1.3-fold (0.12 log units) above what was measured; the measured number falls inside the stated range.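

In the HepG2 assay, putting fluoro in place of hydrogen on the tert-butyl group gives a 1.3-fold lower number from compound 2 to compound 3 (0.11 log units; within the scatter), so this position accepts the swap without a shift that can be told from the scatter. The same single atom matters far more in a physicochemical assay, read by HPLC, with a stated time of 3 h, at pH 1.2 (on this read-out higher numbers stand for a more stable compound and lower numbers for a less stable compound), where compound 2 gives 23% and compound 3 gives 98%, so the two compounds stand far apart: the measured percent of the compound remaining of compound 2, 23%, and of compound 3, 98%, a number 75 percentage points higher (beyond the scatter). This one pair therefore shows that a change invisible in one read-out can be large in another.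

Going by these compounds, whether difluoromethyl, trifluoromethyl, hydroxymethyl or a longer chain at this place would give the same picture stays open. One pair also cannot tell whether this result would hold on a different core.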